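The compounds below may be only part of what the source reports. "The series", "measured", "known", "first", "only" and "open" are said of these compounds alone.

Measured compounds:
compound 1, `Cc1cccc(Cn2c(CN3CCN(C(=O)c4ccc([N+](=O)[O-])cc4)CC3)nc3ccccc32)c1`: 24.3%
compound 2, `CCn1c(CN2CCN(C(=O)C3CC3)CC2)nc2ccccc21`: 20.8%

Of the compounds shown here, two have been measured in an assay on isolated protein for inhibition of aldehyde dehydrogenase 1A1 (Homo sapiens), read by spectrophotometry, tested at 10 uM; a lower number here means less inhibition, a higher number more inhibition at the concentration tested (going by the name of the read-out). Compound 1, with the structure `Cc1cccc(Cn2c(CN3CCN(C(=O)c4ccc([N+](=O)[O-])cc4)CC3)nc3ccccc32)c1`, gives 24.3% in this assay. Compound 2, built as `CCn1c(CN2CCN(C(=O)C3CC3)CC2)nc2ccccc21`, gives 20.8% in this assay. The gap between these two numbers lies within the scatter of repeated measurements, so the two numbers read level in this assay, and neither can be called the higher one on these numbers.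

Compound 3, with the structure `Cc1cccc(Cn2c(CN3CCN(C(=O)c4cccnc4)CC3)nc3ccccc32)c1`, has not yet been measured. It differs from compound 1 in one place:
pyridin-3-yl in place of 4-nitrophenyl on a carbonyl carbon
Going by the values given here, no pair of measured compounds shows what such an exchange does in this assay, so the direction of this step cannot be read from the data at hand. With nothing to point either way, compound 3 is expected to stay close to compound 1. The step of a number 4.3 percentage points lower from compound 1 to compound 3 (within the scatter) is estimated to be no larger than the scatter. The value of compound 3 in this assay is therefore estimated at 20%, within a range from 5% to 40%.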

Compound 3, a percentage reported as inhibition, at one concentration (the size of the read-out at that concentration, not a potency): 24.5%
For compound 3 the middle estimate is 4.5 percentage points below the measured one; the range from low to high includes it.
By their numbers in this assay, from the lowest: compounds 2, 1 and 3 (each within the scatter of the next).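

In this assay, putting pyridin-3-yl in place of 4-nitrophenyl on the carbonyl carbon reads as a number 0.2 percentage points higher from compound 1 to compound 3 (within the scatter), so the two compounds stand level. This is the first pair shown that differs in only one place, and it gives a first direct look at this position: a ring of carbon only carrying a nitro group, 9 heavy atoms in all, and a six-membered aromatic ring with one hetero atom, 6 heavy atoms in all, give readings that cannot be told apart. No measurement at hand explains why these two groups read level.

Compound 2 carries a different group on its carbonyl carbon but also differs from compound 1 and compound 3 elsewhere, so it cannot show what that group alone does. From the compounds shown here alone, it remains open whether any group on this carbonyl carbon would lift the reading beyond the scatter, for example a phenyl ring bearing a carboxylic acid or an amine, or a longer alkyl chain.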